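A few compounds are considered here, and "the series" means these few. Any claim that something is new, unique, unknown or untested is made for them only; others in the source may bear on it.

Measured so far in an assay on U2OS cells for inhibition of secreted frizzled-related protein 1 (Homo sapiens), read by a luciferase reporter, with a stated time of 18 h; on this read-out lower numbers stand for an effect already at smaller amounts and higher numbers for an effect only at larger amounts of compound:
compound 1 `O=C(c1ccc(Cl)cc1)N1CCC(NS(=O)(=O)c2cc(S(=O)(=O)c3ccccc3)ccc2C(F)(F)F)CC1`, 1800 nM
compound 2 `O=C(O)c1ccc(S(=O)(=O)N2CCC(NS(=O)(=O)c3cc(S(=O)(=O)c4ccccc4)ccc3C(F)(F)F)CC2)cc1`, 110 nM
compound 3 `O=C(O)c1ccc(N2CCC(NS(=O)(=O)c3cc(S(=O)(=O)c4ccccc4)ccc3C(F)(F)F)CC2)cc1`, 230 nM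

Compound 1 gives the highest number of the three; nearest is compound 3, a 7.8-fold lower number from compound 1 to compound 3 (0.89 log units; beyond the scatter), furthest compound 2, a 16-fold lower number from compound 1 to compound 2 (1.21 log units; beyond the scatter). Compound 4 `CC(C)(C)OC(=O)N1CCC[C@@H]1C(=O)N1CCC(NS(=O)(=O)c2cc(S(=O)(=O)c3ccccc3)ccc2C(F)(F)F)CC1` differs from compound 1 in one place: 1-(tert-butoxycarbonyl)pyrrolidin-2-yl in place of 4-chlorophenyl on a carbonyl carbon. Both measured steps from compound 1 also alter the group on the amine nitrogen in the ring, but each removes the carbonyl and brings in a 4-carboxyphenyl, which compound 4 does not; between those two, a 2.1-fold higher number from compound 2 to compound 3 (0.32 log units; beyond the scatter). Among the compounds with values here, no measured step exchanges the group on the carbonyl carbon itself, so the direction is open. The expected step of no change at the digits printed from compound 1 to compound 4 (within the scatter) is none beyond the scatter. Compound 4 is estimated at 1800 nM, range 500 nM to 6500 nM.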

Compound 4, half-maximal effective concentration: 210 nM
Compound 4: the middle estimate sits 8.6-fold (0.93 log units) above what was measured; the measured number lies below the stated range.
By their numbers in this assay, from the lowest: compounds 2, 4 and 3 (each within the scatter of the next, the first and the last beyond it); then compound 1.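

With the carbonyl kept and only the group on it exchanged, an 8.6-fold lower number from compound 1 to compound 4 (0.93 log units; beyond the scatter), so this position alone can move the number by more than the scatter. Among the compounds shown, a step from compound 1 beyond the scatter therefore no longer requires a 4-carboxyphenyl or loss of the carbonyl. No measurement at hand explains this step.

Going by these compounds, it remains open which part of the entering group carries the step: the tert-butoxycarbonyl, the five-membered ring or the defined stereocentre. A free amine on that ring would help separate these.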